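A few compounds are considered here, and "the series" means these few. Any claim that something is new, unique, unknown or untested is made for them only; others in the source may bear on it.

Compound 1 `COc1ccc(C(=O)Nc2ccccc2-c2nnn(-c3ccc(OC)cc3)n2)cc1`: 156 nM
Compound 2 `COc1cccc(-n2nnc(-c3ccccc3NC(=O)c3ccc(N)cc3)n2)c1`: 212 nM

Both compounds were tested in a functional assay on NCI-H460 cells (Homo sapiens) for positive allosteric modulation, read by MTT assay, with stated times of 2 h and 72 h, tested at 3 uM; a lower number here means a stronger inhibitor, a higher number a weaker inhibitor. There, compound 1 gives 156 nM and compound 2 gives 212 nM, so the two stand within the scatter of each other. Compound 1 therefore shares the best-measured level with compound 2 and does not stand clear of it.

The next compound to consider is compound 3 `COc1ccc(NC(=O)Nc2ccccc2-c2nnn(-c3ccc(OC)cc3)n2)cc1`, which keeps the core of compound 1 and changes one group: (4-methoxyphenyl)amino in place of 4-methoxyphenyl on a carbonyl carbon. In words, (4-methoxyphenyl)amino takes the place of 4-methoxyphenyl on a carbonyl carbon whose other neighbour is an amide-type nitrogen.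

For the measured compounds named here, no two measured compounds differ in one place only, so the data hold no direct precedent for this change, and any forecast for this assay stays uncertain. A small move toward a higher number is expected, one that may not pass beyond the scatter. The expected size of this move is a 1.4-fold higher number from compound 1 to compound 3 (0.15 log units; within the scatter). For compound 3 the estimate is 220 nM, with an expected range from 70 nM to 700 nM.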

Compound 3, half-maximal inhibitory concentration: 229 nM
Estimate against measurement, compound 3: 1.0-fold (0.02 log units) below; low and high end bracket the measured number.
By their numbers in this assay, from the lowest: compounds 1, 2 and 3 (each within the scatter of the next).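

In this assay, for the compounds shown here, the urea-type compound 3 offers the first comparison in this set that differs from another compound in one place only. Putting (4-methoxyphenyl)amino in place of 4-methoxyphenyl on a carbonyl carbon whose other neighbour is an amide-type nitrogen gives a 1.5-fold higher number from compound 1 to compound 3 (0.17 log units; within the scatter), so the added nitrogen and its hydrogen-bond donor leave the number indistinguishable from that of compound 1. At this position, then, the two linkages to the 4-methoxyphenyl ring cannot be told apart in this assay, and nothing available accounts for how closely the two compounds agree.

The compounds shown leave open how far this tolerance extends, since a single step says nothing about a benzylamino group, with its longer chain, or about a simple methylamino group on the same carbonyl carbon. Going by these compounds, it also remains unknown whether the 4-methoxyphenyl ring is needed at all in the urea series, or whether a 4-chlorophenyl or an unsubstituted phenyl group on that nitrogen would leave the number equally undisturbed.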